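Phenyl ester to isobutyl ketone on the diene chain

This account rests on a few compounds, and the source may have more. Where it says the series, first, only, none or still open, it means among the compounds named here.

Measured so far in a physicochemical assay for lipophilicity; on this read-out lower numbers stand for lower lipophilicity and higher numbers for higher lipophilicity:
compound 1, `CC(/C=C/CC(C)CCCC(C)C)=C\C(=O)Oc1ccccc1`, gives 7.67;
compound 2, `CCOC(=O)/C=C(C)/C=C/CC(C)CCCC(C)(C)C`, gives 7.15;
compound 3, `CCOC(=O)/C=C(C)/C=C/CC(C)CCC=C(C)C`, gives 6.19.

Compound 1 stands highest of the three numbers in this assay. Compound 2 is nearest to it, and compound 3 is furthest; both of those gaps are beyond the scatter of the measurement.

Compound 4, `CC(/C=C/CC(C)CCCC(C)C)=C\C(=O)CC(C)C`, has not yet been measured. It differs from compound 1 by isobutyl in place of phenoxy on a carbonyl carbon. For the measured compounds named here, the only measured step between two compounds that differ in one place is a number 0.96 log units lower from compound 2 to compound 3 (beyond the scatter), and that step concerns a change on a saturated chain carbon, not on the carbonyl carbon, so it does not bear directly on the change from compound 1 to compound 4. Going by the values given here, there is no measured pair that exchanges a phenoxy for an isobutyl on a carbonyl carbon.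

With nothing directly comparable, the expectation rests on the structural change alone: phenoxy with its oxygen leaves and the smaller isobutyl enters. A step of about a number 0.27 log units lower from compound 1 to compound 4 (within the scatter) in this assay is expected, a modest move downward that may not clear the scatter. Compound 4 is accordingly estimated at 7.4, within a range from 6.8 to 8.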

Compound 4, partition coefficient: 7.22
Beside the measured number, compound 4's estimate is 0.18 log units above it; the measured number falls inside the stated range.
By their numbers in this assay, from the lowest: compound 3; then compounds 2 and 4 (each within the scatter of the next); then compound 1.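

In this assay, the carbonyl carbon is a position where a change moves the number, as a number 0.45 log units lower from compound 1 to compound 4 (beyond the scatter) shows; the earlier step concerned only a saturated chain carbon. Isobutyl in place of phenoxy takes away the six-membered aromatic ring and the oxygen in a single change, and it also reduces the group from 7 heavy atoms to 4, so the step belongs to the whole exchange and not to any one of these features. No independent data bear on what underlies the step.

The compounds shown leave the parts of this exchange unseparated: isobutoxy on the same carbonyl carbon would retain the oxygen without the ring, while benzyl would retain the ring without the oxygen. It also remains open whether an exchange at the carbonyl carbon gives a step of similar size when the chain carries neopentyl or 2-methylprop-1-en-1-yl, as no pair shown tests this.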